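This account rests on a few compounds, and the source may have more. Where it says the series, first, only, none or still open, it means among the compounds named here.

Among the compounds with values here, compound 2 `CCC(F)(F)C(=O)N1CCC(Oc2ncnc(Oc3ccc(S(C)(=O)=O)nc3C)c2F)CC1` gives 17.4 nM in a functional assay on isolated protein for inhibition of Glucose-dependent insulinotropic receptor (Homo sapiens), read by HTRF and cAMP accumulation (on this read-out higher numbers stand for an effect only at larger amounts of compound and lower numbers for an effect already at smaller amounts), and stands lowest of the two numbers measured so far; compound 1 `Cc1nc(S(C)(=O)=O)ccc1Oc1ncnc(OC2CCN(C(=O)C(C)(F)F)CC2)c1F` gives 37 nM in this assay. Compound 3 `Cc1nc(S(C)(=O)=O)ccc1Oc1ncnc(OC2CCN(C(=O)c3ncc(Cl)cn3)CC2)c1F` differs from compound 2 by 5-chloropyrimidin-2-yl in place of 1,1-difluoropropyl on a carbonyl carbon. Within the data shown here, the only measured step, a 2.1-fold lower number from compound 1 to compound 2 (0.33 log units; beyond the scatter), alters the same substituent on the carbonyl but keeps a saturated chain there, so it bears only loosely on an aromatic ring entering at that place, and it was modest. Among the measured compounds shown here, no measured step covers a ring on this carbonyl, so the outlook is uncertain in either direction. For compound 3 the expected step is a 1.7-fold higher number from compound 2 to compound 3 (0.24 log units; within the scatter), an estimate of 30 nM with a range from 8 nM to 120 nM.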

Compound 3, half-maximal effective concentration: 6.12 nM
Compound 3: the middle estimate sits 4.9-fold (0.69 log units) above what was measured, outside the stated range (below it).
By their numbers in this assay, from the lowest: compound 3; then compound 2; then compound 1.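

On the carbonyl carbon bound to the amide-type ring nitrogen, an aromatic ring gives lower numbers than either saturated chain in this assay: 5-chloropyrimidin-2-yl in place of 1,1-difluoropropyl gives a 2.8-fold lower number from compound 2 to compound 3 (0.45 log units; beyond the scatter), and in place of 1,1-difluoroethyl it gives a 6.0-fold lower number from compound 1 to compound 3 (0.78 log units; beyond the scatter). The position therefore accepts a larger, six-membered aromatic group in place of a short fluorinated chain. Nothing at hand accounts for the lower number. Still open, on these data alone, is which part of the new group matters, the chlorine or the ring nitrogens; an unsubstituted phenyl ring or a pyrimidin-2-yl without chlorine on this carbonyl would separate the two.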